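Swapping bromo for (4-chlorophenyl)sulfanyl on compound 2

This account rests on a few compounds, and the source may have more. Where it says the series, first, only, none or still open, it means among the compounds named here.

compound 1 `CS(=O)(=O)Cc1nc2c(Br)cc(Cl)cn2c1N` gives the limit > 125000 nM
compound 2 `O=[N+]([O-])c1c(CS(=O)(=O)c2ccccc2)nc2c(Br)cc(C(F)(F)F)cn12` gives the limit > 15600 nM
compound 3 `Cc1cc(Br)c2nc(CS(=O)(=O)c3ccccc3)c([N+](=O)[O-])n2c1` gives the limit > 31200 nM

Within the data shown here, all three readings in an ADME assay on HepG2 cells (Homo sapiens) for cytotoxicity, read by MTT assay, with a stated time of 72 h (on this read-out lower numbers stand for higher toxicity in this test and higher numbers for lower toxicity in this test), are limits, so no compound has a number yet. Compound 2 therefore has no exact place among the others, and it shares this standing with the two further compounds.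

Compound 4 `O=[N+]([O-])c1c(CS(=O)(=O)c2ccccc2)nc2c(Sc3ccc(Cl)cc3)cc(C(F)(F)F)cn12` is compound 2 with one change: (4-chlorophenyl)sulfanyl in place of bromo on an aromatic carbon and the rest unchanged. The added (4-chlorophenyl)sulfanyl brings one six-membered aromatic ring of carbon only.

Among the measured compounds shown here, the only measured step is a step that the two limits leave unreadable from compound 2 to compound 3 and it concerns methyl in place of trifluoromethyl on an aromatic carbon, a different change from this one. It offers neither a size nor a direction for the bromo replacement. The expectation rests on compound 2 alone, with its limit > 15600 nM as the anchor.

The expected step is an at least 1.2-fold lower number from compound 2 to compound 4 (0.07 log units; that floor lies within the scatter) and it is only a weak estimate, with another limit quite possible in this assay.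

Compound 4 is estimated at 13000 nM with an expected range from 3500 nM to 45000 nM.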

Compound 4, half-maximal cytotoxic concentration: > 7800 nM
Compound 4 was reported as a limit (the forecaster's own chance of this, stated with the estimate: 65%); the middle value does not contradict the limit.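

In this assay compound 4 gives the limit > 7800 nM. Compound 2 gives the limit > 15600 nM. These two limits leave the step from compound 2 to compound 4 unreadable. The compounds shown leave open what exact half-maximal cytotoxic concentration any of them has, and what size or direction the bromo replacement has.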